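The source may report more compounds than this note shows. Statements on the series, on what has been measured and on what is new or still open speak of the compounds shown alone.

Values in an ADME assay on L1210/0 cells (Mus musculus) for cytotoxicity, with a stated time of 48 h; a higher number here means a weaker inhibitor, a lower number a stronger inhibitor:
Compound 1 `O=c1[nH]c(=O)n([C@H]2C[C@H](O)[C@@H](CO)O2)cc1/C=N/O`: 15500 nM
Compound 2 `O=c1[nH]c(=O)n([C@H]2C[C@H](O)[C@@H](CO)O2)cc1C#CCCCO`: > 200000 nM, a limit and not a number

Compound 2 has no number of its own and stands at the limit of > 200000 nM in this assay, at which 1 of the 2 values shown sits. The next compound is compound 3 `C[S+]([O-])c1cn([C@H]2C[C@H](O)[C@@H](CO)O2)c(=O)[nH]c1=O`, which differs from compound 2 on an aromatic carbon of the shared core: a group of 3 heavy atoms (1 carbon, 1 oxygen, 1 sulfur; no ring) in place of a group of 6 heavy atoms (5 carbon, 1 oxygen; no ring), on an aromatic carbon. There, 5-hydroxypent-1-yn-1-yl leaves and a group of 3 heavy atoms enters.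

For the measured compounds named here, only one measured step bears on this change. In compound 1 a group of 3 heavy atoms also sits on an aromatic carbon, and an at least 12-fold higher number from compound 1 to compound 2 (1.11 log units; beyond the scatter) is large and beyond the scatter. The change to compound 3 runs the opposite way, so a lower number is expected, and the fall may be large. Going by the values given here, the support is thin, however, since the group entering in compound 3 is not the one carried by compound 1, and compound 3 could also remain at the limit.

The expected step is an at least 4.0-fold lower number from compound 2 to compound 3 (0.60 log units; beyond the scatter). Compound 3 is estimated at 50000 nM, with an expected range of 10000 nM to 200000 nM.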

Compound 3, half-maximal inhibitory concentration: > 200000 nM
Compound 3 ended at the assay's limit; the forecaster's own chance of this, stated with the estimate: 35%; middle value at least 4.0-fold (0.60 log units) away from the limit.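

In this assay compound 3 gives > 200000 nM, a limit of the assay and not a number. For the compounds shown here, putting a group with the same count of heavy atoms in place of the one in compound 1 still gives an at least 12-fold higher number from compound 1 to compound 3 (1.11 log units; beyond the scatter), so at this position a small group alone does not bring a number like that of compound 1. The step between compound 2 and compound 3 cannot be read, and two quite different groups on this aromatic carbon, 5-hydroxypent-1-yn-1-yl and the one holding sulfur, now share the same limit: the limit of > 200000 nM in this assay, at which 2 of the 3 values shown sit.

Only compound 1 has a true number, so the compounds shown cannot tell whether compound 2 and compound 3 differ from each other, nor which part of the group in compound 1 goes with its lower number. Going by these compounds, how an amine or a carboxylic acid on the same aromatic carbon would read in this assay, and whether either would give a number rather than a limit, remains open.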